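The source may hold more compounds than are shown below. What is called first, only, known or untested is meant among the compounds shown, and "the series" means these compounds.

The piece follows a change made to compound 1, whose structure is `CS(=O)(=O)c1ccc(C(=O)NC(=O)c2ccccc2O)cc1`. In an ADME assay on L6 cells (Rattus norvegicus) for cytotoxicity, read by resazurin assay, with a stated time of 72 h (a lower number here means a stronger inhibitor, a higher number a weaker inhibitor), compound 1 gives > 100 ug/mL, which is a limit of the assay rather than a number. Two other compounds built on the same core have returned numbers. Compound 2, with the structure `O=C(NC(=O)c1ccccc1O)c1cccc(CCl)c1`, gives 1.8 ug/mL in this assay. Compound 3, with the structure `O=C(NC(=O)c1ccc(Cl)cc1Cl)c1ccccc1O`, gives 62 ug/mL in this assay. Compound 1 therefore stands at the edge of what the assay can report, at the point where one of the three values sits (the limit of > 100 ug/mL in this assay, at which 1 of the 3 values shown sits), while compound 2 and compound 3 lie inside the measurable range.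

The compound not yet measured is compound 4, with the structure `Nc1ccc(C(=O)NC(=O)c2ccccc2O)cc1`. It differs from compound 1 in a single place: amino in place of methylsulfonyl on an aromatic carbon. No measured pair among these three differs in only one place, so no measured step can be carried over directly. Because compound 1 sits at the limit of > 100 ug/mL in this assay, at which 1 of the 3 values shown sits, the starting point itself is open-ended. The step from compound 1 to compound 4 is expected to be an at least 1.1-fold lower number from compound 1 to compound 4 (0.04 log units; that floor lies within the scatter), no larger than the scatter of repeated measurements. Compound 4 is expected to give 90 ug/mL, with a range from 30 ug/mL to 200 ug/mL, and may well return only a limit again.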

Compound 4, half-maximal inhibitory concentration: 39 ug/mL
Compound 4: the middle estimate sits 2.3-fold (0.36 log units) above what was measured, and the stated range covers the measured number.
By their numbers in this assay, from the lowest: compound 2; then compounds 4 and 3 (each within the scatter of the next). At a limit, above all of these: compound 1.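

Among these compounds, replacing methylsulfonyl with amino on this aromatic carbon, para to a large group, is the only change here that can be read in a single place, and in this assay it gives an at least 2.5-fold lower number from compound 1 to compound 4 (0.40 log units; beyond the scatter). The change brings the series off the assay's limit and yields a real number, which shows that the result in this assay depends on the group carried at this carbon of the shared core. The size of the step can be stated only as a minimum, because compound 1 gives a limit and not a number: the limit of > 100 ug/mL in this assay, at which 1 of the 4 values shown sits.

With a single pair to read, the compounds shown leave open whether the lower number comes from gaining the amino group or from losing methylsulfonyl, and they give no reason for the step. As far as these compounds go, it also remains open how other groups on this same carbon would compare with compound 4, such as a hydroxyl, a methyl, a carboxylic acid or a dimethylamino group, and whether any of them would move the number further in either direction.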